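The source may report more compounds than this note shows. Statements on the series, on what has been measured and on what is new or still open speak of the compounds shown alone.

Compound 2 `CN1CCN(CC(=O)N2N=C(c3cc4ccccc4oc3=O)CC2c2ccccc2)CC1` is one of two pyrazoline amides carrying the same core. In a functional assay on HepG2 cells (Homo sapiens) for cytotoxicity, read by MTT assay, with a stated time of 48 h (a lower number here means a stronger inhibitor, a higher number a weaker inhibitor), compound 2 gives 33100 nM, the highest of the two numbers measured. Its nearest neighbour, compound 1 `O=C(CCl)N1N=C(c2cc3ccccc3oc2=O)CC1c1ccccc1`, gives 2980 nM in this assay; the step of an 11-fold higher number from compound 1 to compound 2 (1.05 log units; beyond the scatter) is large and lies beyond the scatter.

Compound 3 `NC(=O)C1CCN(CC(=O)N2N=C(c3cc4ccccc4oc3=O)CC2c2ccccc2)CC1` is not yet measured. It differs from compound 2 in a single place: 4-carbamoylpiperidin-1-yl in place of 4-methylpiperazin-1-yl on a saturated chain carbon bound to a carbonyl carbon. Within the data shown here, no measured pair shows this exchange of one saturated six-membered amine ring for another. Among the measured compounds shown here, the only step available, an 11-fold higher number from compound 1 to compound 2 (1.05 log units; beyond the scatter), tells of the replacement of chloro by 4-methylpiperazin-1-yl, a change of a different kind, so it bears on the new step only loosely, as a sign that this position tolerates a sizeable change in the number. For the measured compounds named here, with no direct precedent, the expected step of a 1.1-fold lower number from compound 2 to compound 3 (0.04 log units; within the scatter) is small and not beyond the scatter in either direction. Compound 3 is therefore estimated at 30000 nM in this assay, within a range from 9000 nM to 100000 nM.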

Compound 3, half-maximal inhibitory concentration: 19300 nM
Beside the measured number, compound 3's estimate is 1.6-fold (0.19 log units) above it, within the range that was stated.
By their numbers in this assay, from the lowest: compound 1; then compounds 3 and 2 (each within the scatter of the next).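

In this assay, exchanging one saturated six-membered amine ring for another on the saturated chain carbon bound to a carbonyl carbon gives a 1.7-fold lower number from compound 2 to compound 3 (0.23 log units; within the scatter) and so does not separate 4-methylpiperazin-1-yl from 4-carbamoylpiperidin-1-yl, although the entering group has one hetero atom in the ring instead of two and adds a hydrogen-bond donor. The replacement of chloro by this second ring gives a 6.5-fold higher number from compound 1 to compound 3 (0.81 log units; beyond the scatter) and thus shows that the gap first seen with compound 2 is not confined to 4-methylpiperazin-1-yl, with neither ring-bearing compound going against it among these three compounds. The data at hand offer no measurement that accounts for this gap.

From the compounds shown here alone, it remains open whether the gap belongs to chloro itself or to the rings, which a bromo group or an open-chain amine such as dimethylamino at the same carbon could begin to separate. Going by these compounds, it also remains open how far the ring can vary at this carbon, for instance with morpholine or with a piperidine bearing a carboxylic acid.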